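One Aryl Exchange Repeated on a Second Core

The source may hold more compounds than are shown below. What is called first, only, known or untested is meant among the compounds shown, and "the series" means these compounds.

Measured in a functional assay on CCRF-CEM cells (Homo sapiens), read by MTT assay, with a stated time of 72 h; on this read-out higher numbers stand for weaker inhibition and lower numbers for stronger inhibition:
Compound 1 `CN(C)c1ncnc2c1c(-c1ccoc1)cn2[C@@H]1O[C@H](CO)[C@@H](O)[C@H]1O`: 13300 nM
Compound 2 `CN(C)c1ncnc2c1c(-c1cc3ccccc3o1)cn2[C@@H]1O[C@H](CO)[C@@H](O)[C@H]1O`: a limit of this assay, > 20000 nM
Compound 3 `Nc1nc(N)c2c(-c3ccoc3)cn([C@@H]3O[C@H](CO)[C@@H](O)[C@H]3O)c2n1`: a limit of this assay, > 20000 nM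

Compound 1 and compound 2 share a core and differ in one place, (1-benzofuran-2-yl in place of furan-3-yl on an aromatic carbon). Across this change the read-out moves by an at least 1.5-fold higher number from compound 1 to compound 2 (0.17 log units; that floor lies within the scatter). The value of compound 2 is a limit of this assay and not a number. Compound 3 is built on a different core, and the difference between the two cores is not broken down here. The value of compound 3 is likewise a limit of this assay. The unmeasured compound 4 `Nc1nc(N)c2c(-c3cc4ccccc4o3)cn([C@@H]3O[C@H](CO)[C@@H](O)[C@H]3O)c2n1` stands to compound 3 as compound 2 stands to compound 1: 1-benzofuran-2-yl in place of furan-3-yl on an aromatic carbon, the same change at the same place. Within the data shown here, two of the three values so far sit at the limit of > 20000 nM in this assay, at which 2 of the 3 values shown sit. The step from compound 3 to compound 4 is expected to be a step that the limit leaves unreadable from compound 3 to compound 4. This expectation rests on compound 3, whose value is already the limit > 20000 nM. It also rests on the direction of an at least 1.5-fold higher number from compound 1 to compound 2 (0.17 log units; that floor lies within the scatter). Compound 4 is therefore expected at 40000 nM, most likely reported as a limit rather than a number, within 20000 nM to 120000 nM.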

Compound 4, half-maximal inhibitory concentration: > 20000 nM
Compound 4 was reported as a limit (the forecaster's own chance of this, stated with the estimate: 85%); the middle value lies beyond the limit too.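

Compound 4, like compound 3, is reported only as a limit and not as a number, so no step can be read from compound 3 to compound 4: the limit of > 20000 nM in this assay, at which 3 of the 4 values shown sit. The compounds shown leave open whether 1-benzofuran-2-yl in place of furan-3-yl moves the read-out at all on the core of compound 3, and by how much.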